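This account rests on a few compounds, and the source may have more. Where it says the series, first, only, none or still open, it means among the compounds named here.

Working notes on the series. The shared core is varied at the amine nitrogen in a ring. Compound 1 `CN1CCc2nc(C#Cc3ccccc3)sc2C1` carries methyl there; in an assay on HEK293 cells for negative allosteric modulation of metabotropic glutamate receptor 5 (Homo sapiens), read by FLIPR, with a stated time of 1 h (on this read-out higher numbers stand for weaker inhibition and lower numbers for stronger inhibition), compound 1 gives only a limit of the assay, > 10000 nM. Compound 2 `C(#Cc1nc2c(s1)CN(C1CCCCC1)CC2)c1ccccc1` carries cyclohexyl and in this assay compound 2 likewise gives only a limit, > 10000 nM. Compound 3 `O=C(C1CCC1)N1CCc2nc(C#Cc3ccccc3)sc2C1` carries cyclobutylcarbonyl, and in this assay compound 3 gives 370 nM. For the measured compounds named here, that is the only numerical value shown; the other two values sit at the limit of > 10000 nM in this assay, at which 2 of the 3 values shown sit. The steps of an at least 27-fold lower number from compound 1 to compound 3 (1.43 log units; beyond the scatter) and an at least 27-fold lower number from compound 2 to compound 3 (1.43 log units; beyond the scatter) are both large and both read only as lower bounds. Compound 4 `CC1CC(C(=O)N2CCc3nc(C#Cc4ccccc4)sc3C2)C1` differs from compound 3 by methyl in place of hydrogen on a saturated ring carbon. All measured steps concern the group on the amine nitrogen, not the cyclobutyl ring, so none of them bears directly on this change. In this assay the expected step is therefore none beyond the scatter, the estimated step being a 1.1-fold lower number from compound 3 to compound 4 (0.02 log units; within the scatter). Compound 4 is expected to give 350 nM, within a range of 120 nM to 1100 nM.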

Compound 4, half-maximal inhibitory concentration: > 10000 nM
Compound 4: a limit, no number; the forecaster's own chance of this, stated with the estimate: 5%; middle value at least 28-fold (1.45 log units) away from the limit.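

In this assay compound 4 gives only a limit of the assay, > 10000 nM. For the compounds shown here, the cyclobutyl ring proves not to be a free place: methyl in place of hydrogen on a saturated ring carbon, two ring bonds from the ring atom that bears a large group, gives an at least 27-fold higher number from compound 3 to compound 4 (1.43 log units; beyond the scatter), whereas the earlier steps concerned only the group on the amine nitrogen. The steps from the two other limit compounds to compound 4 cannot be read, and compound 3 stays the only compound of the series with a number: the limit of > 10000 nM in this assay, at which 3 of the 4 values shown sit.

From the compounds shown here alone, how far the step runs past its lower bound stays open. Also open, going by these compounds, is whether fluorine or hydroxyl on the same ring carbon, or a cyclopentylcarbonyl group on the amine nitrogen, would leave a readable value.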